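The compounds below may be only part of what the source reports. "The series", "measured", "known", "first", "only" and "open" are said of these compounds alone.

Measured so far in a functional assay on MDA-MB-231 cells (Homo sapiens) for antiproliferative activity, read by CCK-8 assay, with a stated time of 72 h; on this read-out higher numbers stand for weaker inhibition and lower numbers for stronger inhibition:
compound 1, `O=C(Nc1cccc(-c2oc3cc(-c4ccc(F)cc4)ccc3c(=O)c2O)c1)c1ccccc1F`, 7240 nM
compound 2, `O=C(Nc1cccc(-c2oc3cc(-c4ccc(F)cc4)ccc3c(=O)c2O)c1)c1ccc(F)cc1F`, 11200 nM
compound 3, `COc1ccccc1C(=O)Nc1cccc(-c2oc3cc(-c4ccc(F)cc4)ccc3c(=O)c2O)c1`, 5110 nM

Compound 3 and compound 1 lie within the scatter of each other (a 1.4-fold lower number from compound 1 to compound 3 (0.15 log units; within the scatter)), while against compound 2 compound 3 shows a modest step to a lower number (a 2.2-fold lower number from compound 2 to compound 3 (0.34 log units; beyond the scatter)).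

Compound 4, `O=C(Nc1cccc(-c2oc3cc(-c4ccc(F)cc4)ccc3c(=O)c2O)c1)c1cccc(F)c1`, differs from compound 3 by 3-fluorophenyl in place of 2-methoxyphenyl on a carbonyl carbon. For the measured compounds named here, two measured steps bear on this. Exchanging fluoro for methoxy on the amide aryl ring gave a 1.4-fold lower number from compound 1 to compound 3 (0.15 log units; within the scatter), and adding a second fluoro gave a 1.5-fold higher number from compound 1 to compound 2 (0.19 log units; within the scatter); both are small. Returning to a fluorophenyl amide is therefore expected to move the number back toward compound 1, a step no larger than a 1.5-fold higher number from compound 3 to compound 4 (0.17 log units; within the scatter). Compound 4 is expected to give 7500 nM, in the range 4000 nM to 15000 nM.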

Compound 4, half-maximal inhibitory concentration: 2510 nM
For compound 4 the middle estimate is 3.0-fold (0.48 log units) above the measured one; the whole stated range lies above it.
By their numbers in this assay, from the lowest: compound 4; then compounds 3, 1 and 2 (each within the scatter of the next, the first and the last beyond it).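

In this assay, the place of a single fluoro on the amide aryl ring now matters: 3-fluorophenyl in place of 2-fluorophenyl gives a step beyond the scatter (a 2.9-fold lower number from compound 1 to compound 4 (0.46 log units; beyond the scatter)), whereas adding a fluoro to compound 1 stayed within it. The same group also beats the other two aryl groups (a 2.0-fold lower number from compound 3 to compound 4 (0.31 log units; beyond the scatter); a 4.5-fold lower number from compound 2 to compound 4 (0.65 log units; beyond the scatter)), so compound 4 has the lowest number of the four. Nothing available explains this difference.

Going by these compounds, whether 3-methoxyphenyl, 3-chlorophenyl or 3-aminophenyl on the same carbonyl carbon would hold or lower this number remains open.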